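Swapping the aryl cap on a piperazine-linked oxindole series

The compounds below may be only part of what the source reports. "The series", "measured", "known", "first", "only" and "open" are said of these compounds alone.

Of the compounds shown here, three with a shared core have been measured in an assay on CHO cells for displacement of a labelled ligand from 5-hydroxytryptamine receptor 7 (Homo sapiens); on this read-out lower numbers stand for stronger inhibition and higher numbers for weaker inhibition. Compound 1, `CCC1(CCCN2CCN(c3cccc(Cl)c3)CC2)C(=O)Nc2ccccc21`, gives 21 nM. Compound 2, `CCC1(CCCCN2CCN(c3ccc(Cl)cc3)CC2)C(=O)Nc2cc(F)c(Cl)cc21`, gives 6.99 nM. Compound 3, `CCC1(CCCCN2CCN(c3ccccc3OC)CC2)C(=O)Nc2ccccc21`, gives 5.38 nM, the lowest number of the three; its gap to compound 2 lies within the scatter of the assay, while its gap to compound 1 lies beyond it.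

Compound 4, `CCC1(CCCCN2CCN(c3ccc(F)c(Cl)c3)CC2)C(=O)Nc2ccccc21`, differs from compound 3 in one place: 3-chloro-4-fluorophenyl in place of 2-methoxyphenyl on an amine nitrogen in a ring. Among the compounds with values here, no measured pair shows this exact swap, so the size of the step can only be guessed. Compound 2 carries a halogen-bearing aryl group on the ring amine nitrogen and gives 6.99 nM, and compound 1 carries one too and gives 21 nM, so a loss of strength beyond the scatter is possible but not certain. The expected step from compound 3 to compound 4 is a 1.9-fold higher number from compound 3 to compound 4 (0.27 log units; within the scatter). For compound 4 in this assay the estimate is 10 nM, with a likely range from 3.5 nM to 30 nM.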

Compound 4, inhibition constant: 0.6 nM
For compound 4 the middle estimate is 17-fold (1.22 log units) above the measured one; the measured number lies below the stated range.
By their numbers in this assay, from the lowest: compound 4; then compounds 3 and 2 (each within the scatter of the next); then compound 1.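

Within the data shown here, this is the first clean one-place comparison, and it shows that the aryl cap on the ring amine nitrogen matters in this assay: 3-chloro-4-fluorophenyl in place of 2-methoxyphenyl gives a 9.0-fold lower number from compound 3 to compound 4 (0.95 log units; beyond the scatter). The two caps have the same number of heavy atoms, and the entering one has no hydrogen-bond acceptor, so at least in this pair, the oxygen of the methoxy group is not needed for a low number. Nothing shown here explains why the step is this large.

The compounds shown cannot separate the contribution of the chlorine from that of the fluorine. Going by these compounds, it also remains open how other caps, such as a pyridine ring or a trifluoromethyl-bearing phenyl, would behave on this nitrogen, and whether this step would hold on the halogenated core of compound 2.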